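Swapping Trimethoxyphenyl for Furan on a Dienone Chain

The source may hold more compounds than are shown below. What is called first, only, known or untested is meant among the compounds shown, and "the series" means these compounds.

Of the compounds shown here, two sharing the same core have been tested in a functional assay on HCT-116 cells (Homo sapiens) for inhibition, read by sulforhodamine B assay, with a stated time of 48 h, tested at 50 uM; on this read-out lower numbers stand for less inhibition of growth and higher numbers for more inhibition of growth at the one concentration tested. Compound 1 `COc1cc(/C=C/C(=O)/C=C/c2cc(OC)c(OC)c(OC)c2)ccc1OCc1cn(CCCCCOc2cc(=O)oc3ccccc23)nn1` gives 53% in this assay. Compound 2 `COc1cc(/C=C/C(=O)/C=C/c2cc(OC)c(OC)c(OC)c2)ccc1OCc1cn(CCCOc2cc(=O)oc3ccccc23)nn1`, which carries a shorter chain to the coumarin unit, gives 76% in this assay. Of these two numbers, compound 1 stands lowest, and the gap to compound 2 lies beyond the scatter of repeated measurements.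

Compound 3 `COc1cc(/C=C/C(=O)/C=C/c2ccco2)ccc1OCc1cn(CCCCCOc2cc(=O)oc3ccccc23)nn1` has not yet been measured in this assay. Its difference from compound 1 is furan-2-yl in place of 3,4,5-trimethoxyphenyl on a double-bonded chain carbon bound to a double-bonded chain carbon. For the measured compounds named here, no measured pair shows what such a change does on this core, so the expectation rests on compound 1 alone and on the fact that a large aromatic group with three oxygen acceptors gives way to a small five-membered ring with one.

The step from compound 1 to compound 3 is expected to be a modest decrease, a number 11 percentage points lower from compound 1 to compound 3 (beyond the scatter), though it could also fall within the scatter. Compound 3 is therefore estimated to give 42% in this assay, within a range from 18% to 66%.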

Compound 3, percent growth inhibition at one concentration: 37%
Estimate against measurement, compound 3: 5 percentage points above; the range from low to high includes it.
By their numbers in this assay, from the lowest: compound 3; then compound 1; then compound 2.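

For the compounds shown here, exchanging the 3,4,5-trimethoxyphenyl for furan-2-yl on a double-bonded chain carbon bound to a double-bonded chain carbon gives, in this assay, a number 16 percentage points lower from compound 1 to compound 3 (beyond the scatter), the first measured step at this place on the shared core. The group at this place therefore matters for the read-out, and here the entering ring, with 5 heavy atoms and 1 hydrogen-bond acceptor, goes with less inhibition of growth than the leaving ring, with 12 heavy atoms and 3 hydrogen-bond acceptors, although this is a single pair and sets no general pattern. Nothing available explains the drop, so the step stands as an observation only.

This one exchange changes ring type, ring size and oxygen count together, so it cannot tell which of them goes with the lower number; a plain phenyl ring or a thiophen-2-yl ring at the same place would help to pull these apart. As far as these compounds go, it also remains open whether furan-2-yl would bring a step of similar size on the shorter chain to the coumarin unit carried by compound 2.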